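Chain step from compound 3 to compound 4

The compounds below may be only part of what the source reports. "The series", "measured", "known", "first", "only" and "open" are said of these compounds alone.

Measured in an in vitro ADME assay on microsomes from liver (Homo sapiens) for metabolic stability, tested at 5 uM; on this read-out lower numbers stand for a shorter-lived compound and higher numbers for a longer-lived compound:
- compound 1 `CS(=O)(=O)Nc1ccc2c(c1)S(=O)(=O)N=C(c1c(O)c(-c3ccsc3)nn(CCC3CC3)c1=O)N2`: 0.517 h
- compound 2 `CS(=O)(=O)Nc1ccc2c(c1)S(=O)(=O)N=C(c1c(O)c(-c3ccc(Cl)s3)nn(CCC3CC3)c1=O)N2`: > 1 h, a limit
- compound 3 `CCC(C)(C)Cn1nc(-c2cccs2)c(O)c(C2=NS(=O)(=O)c3cc(NS(C)(=O)=O)ccc3N2)c1=O`: > 1 h, a limit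

Compound 3 has no number on this read-out. Compound 3 gives only a limit, > 1 h. The same holds for much of this small set: the limit of > 1 h in this assay, at which 2 of the 3 values shown sit.

Compound 4 `CS(=O)(=O)Nc1ccc2c(c1)S(=O)(=O)N=C(c1c(O)c(-c3cccs3)nn(CCC3CC3)c1=O)N2` has cyclopropylmethyl in place of 1,1-dimethylpropyl on a saturated chain carbon bound to an aromatic nitrogen. Cut one bond further out, this is 2,2-dimethylbutyl to 2-cyclopropylethyl.

For the measured compounds named here, no measured step covers this change. Going by the values given here, the only measured step is an at least 1.9-fold higher number from compound 1 to compound 2 (0.28 log units; that floor lies within the scatter), and it lies on an aromatic carbon, not on the chain, so it bears only indirectly. The 2-cyclopropylethyl chain of compound 4 is also carried by compound 1, and compound 1 gives 0.517 h, a true number. Compound 2 carries the same chain and gives > 1 h, which is a limit. The chain therefore does not settle the outcome, but compound 1 at 0.517 h points towards a shorter half-life.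

The expected step is an at least 1.6-fold lower number from compound 3 to compound 4 (0.22 log units; that floor lies within the scatter), towards a lower number, and its size is uncertain. For compound 4 the estimate is 0.6 h, with an expected range from 0.3 h to 1.2 h.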

Compound 4, half-life: > 1 h
Compound 4 gave a limit, no number (the forecaster's own chance of this, stated with the estimate: 25%); middle value at least 1.6-fold (0.22 log units) away from the limit.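

With the 2-cyclopropylethyl chain held constant, thiophen-2-yl in place of thiophen-3-yl gives an at least 1.9-fold higher number from compound 1 to compound 4 (0.28 log units; that floor lies within the scatter) in this assay, so this change at the aromatic carbon has a readable direction only as a floor that does not clear the usual scatter. Compound 4 gives > 1 h, which is a limit, and the 2-cyclopropylethyl chain now appears with a limit on the thiophen-2-yl compound as well as on the 5-chlorothiophen-2-yl compound. The steps to compound 4 from compound 3 and from compound 2 cannot be read, with limits at both ends, so neither the exchange of 1,1-dimethylpropyl for cyclopropylmethyl nor the exchange of chloro for hydrogen has a size here: the limit of > 1 h in this assay, at which 3 of the 4 values shown sit.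

Going by these compounds, how far compound 2, compound 3 and compound 4 each lie beyond that limit remains open, and with it any ranking of the two chains or of the thiophene substituents. Also open, on these data alone, is whether a chain ending in an amine or a carboxylic acid at this position on the aromatic nitrogen would give a true number in this assay.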